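One side group exchanged at the assay limit

A few compounds are considered here, and "the series" means these few. Any claim that something is new, unique, unknown or untested is made for them only; others in the source may bear on it.

Compound 1 `CCC(CC)[C@H](NC(C)=O)[C@@H]1[C@H](OC(=O)NCCCOC(=O)/C=C/c2ccc(O)c(O)c2)[C@@H](C(=O)O)C[C@H]1NC(=N)N`: > 100000 nM
Compound 2 `CCC(CC)[C@H](NC(C)=O)[C@@H]1[C@H](OC(=O)NCCCNC(=O)/C=C/c2ccc(O)c(O)c2)[C@@H](C(=O)O)C[C@H]1NC(=N)N`: > 100000 nM

Both compounds were tested in an ADME assay on MDCK cells (Canis lupus familiaris) for cytotoxicity, with a stated time of 48 h; a higher number here means that more compound is tolerated, a lower number that less compound is tolerated. Compound 1 gives > 100000 nM, which is a limit of the assay and not a number. Compound 2 gives > 100000 nM, which is also a limit. Compound 1 therefore stands at the limit of > 100000 nM in this assay, at which 2 of the 2 values shown sit, and it has no numeric value to start from.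

Compound 3 `CCC(CC)[C@H](NC(C)=O)[C@@H]1[C@H](OC(=O)NCCCOCCCc2ccc(O)c(O)c2)[C@@H](C(=O)O)C[C@H]1NC(=N)N` keeps the core of compound 1 and exchanges one group, on an oxygen on a saturated carbon: a group of 11 heavy atoms (9 carbon, 2 oxygen; one six-membered aromatic ring of carbon only) in place of a group of 12 heavy atoms (9 carbon, 3 oxygen; one six-membered aromatic ring of carbon only), on an oxygen on a saturated carbon. The group that leaves is (2-(3,4-dihydroxyphenyl)ethenyl)carbonyl, and the group that enters has no common name. Each of the two carries one six-membered aromatic ring of carbon only.

For the measured compounds named here, no measured step is available to size this change. No step beyond the scatter is expected in this assay, in either direction, and the estimated change is a number no higher from compound 1 to compound 3 (the limit leaves the size open). This expectation rests on compound 1 alone, whose > 100000 nM is a limit. For compound 3 the estimated value is 100000 nM, with an expected range from 50000 nM to 200000 nM.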

Compound 3, half-maximal cytotoxic concentration: > 100000 nM
Compound 3 ended at the assay's limit (the forecaster's own chance of this, stated with the estimate: 85%); the middle value sits exactly at the limit.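

In this assay compound 3 gives > 100000 nM, which is a limit of the assay and not a number. For the compounds shown here, no step from compound 1 to compound 3 can be read, as all three compounds share this limit: the limit of > 100000 nM in this assay, at which 3 of the 3 values shown sit. The compounds shown leave open whether exchanging this group changes how much compound the cells tolerate.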